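The compounds below may be only part of what the source reports. "The series", "measured", "known", "first", "only" and "open" are said of these compounds alone.

Compound 1 `O=C(Nc1ccccc1[N+](=O)[O-])N[C@H]1CC[C@H](Oc2ccc(F)cc2)CC1`: 3500 nM
Compound 2 `COc1cccc(NC(=O)N[C@H]2CC[C@H](Oc3ccc(F)cc3)CC2)c1`: 14000 nM
Compound 3 `O=C(Nc1ccccc1Cl)N[C@H]1CC[C@H](Oc2ccc(F)cc2)CC1`: 9100 nM

In a functional assay on CRL2813 cells (Homo sapiens) for cytotoxicity, read by sulforhodamine B assay, with a stated time of 5 days (on this read-out lower numbers stand for stronger inhibition and higher numbers for weaker inhibition), compound 3 stands second highest of these three numbers. The step of a 1.5-fold lower number from compound 2 to compound 3 (0.19 log units; within the scatter) lies within the scatter, whereas the step of a 2.6-fold higher number from compound 1 to compound 3 (0.41 log units; beyond the scatter) lies beyond it. Compound 4 `O=C(Nc1ccccc1I)N[C@H]1CC[C@H](Oc2ccc(F)cc2)CC1` is the next compound; it differs from compound 3 by iodo in place of chloro on an aromatic carbon. Going by the values given here, no measured step exchanges one halogen for another. The nearest comparison is a 2.6-fold higher number from compound 1 to compound 3 (0.41 log units; beyond the scatter), a modest step in which a chloro entered for a nitro. Swapping one halogen for another is a smaller change than that, so the expectation is a step no larger than the scatter, a 1.3-fold lower number from compound 3 to compound 4 (0.11 log units; within the scatter). Compound 4 is therefore expected to give 7000 nM, estimated between 2500 nM and 20000 nM.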

Compound 4, half-maximal inhibitory concentration: > 20000 nM
Compound 4 was reported as a limit; the forecaster's own chance of this, stated with the estimate: 5%; middle value at least 2.8-fold (0.45 log units) from the limit.
By their numbers in this assay, from the lowest: compound 1; then compounds 3 and 2 (each within the scatter of the next). At a limit, above all of these: compound 4.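

In this assay, the value of compound 4 is a limit and not a number: the limit of > 20000 nM in this assay, at which 1 of the 4 values shown sits. At this position, on an aromatic carbon ortho to a large group, exchanging one halogen for another is not a silent change, since iodo in place of chloro gives an at least 2.1-fold higher number from compound 3 to compound 4 (0.34 log units; beyond the scatter). The other comparisons show an at least 5.7-fold higher number from compound 1 to compound 4 (0.75 log units; beyond the scatter) and an at least 1.4-fold higher number from compound 2 to compound 4 (0.15 log units; that floor lies within the scatter), so only the first of these two separates the pair.

Going by these compounds, how bromo or an amine would read at this position stays open. So does how far beyond its limit compound 4 lies.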